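The source may report more compounds than this note shows. Statements on the series, on what has been measured and on what is new or still open speak of the compounds shown alone.

Measured in an ADME assay on microsomes from liver (Homo sapiens) for metabolic stability, read by LC-MS, using NADPH, with stated times of 5 min and 30 min, tested at 1 uM; on this read-out higher numbers stand for fast clearance and lower numbers for slow clearance:
- Compound 1 `C[C@@H]1CC(=O)N(c2cnc(NCc3c(F)ccc4c3CCO4)n3cnnc23)C1`: < 3 mL.min-1.g-1, a limit of the assay, not a number
- Compound 2 `CN(c1ccccc1)c1cnc(NCc2c(F)ccc3c2CCO3)n2cnnc12`: 55 mL.min-1.g-1
- Compound 3 `CN(c1ccn(C)n1)c1cnc(NCc2c(F)ccc3c2CCO3)n2cnnc12`: 11 mL.min-1.g-1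

Compound 3 has the lower of the two actual numbers, with compound 2 above it. Compound 4 `CN(C(=O)c1ccccc1)c1cnc(NCc2c(F)ccc3c2CCO3)n2cnnc12` carries benzoyl in place of 1-methyl-1H-pyrazol-3-yl on a nitrogen on an aromatic ring. Among the measured compounds shown here, two measured steps bear on this. Replacing phenyl with 1-methyl-1H-pyrazol-3-yl gave a 5.0-fold lower number from compound 2 to compound 3 (0.70 log units; beyond the scatter), a modest step, so the return of a carbon-only aromatic ring points upward. Against that, the carbonyl-bearing 4-methyl-2-oxopyrrolidin-1-yl sits at the low end, with an at least 3.6-fold higher number from compound 1 to compound 3 (0.56 log units; beyond the scatter), so the carbonyl of benzoyl may hold the rise back. A modest rise is therefore expected, a 2.3-fold higher number from compound 3 to compound 4 (0.36 log units; beyond the scatter). Compound 4 is estimated at 25 mL.min-1.g-1, with an expected range of 9 mL.min-1.g-1 to 65 mL.min-1.g-1.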

Compound 4, intrinsic clearance in microsomes: > 300 mL.min-1.g-1
Compound 4: only a limit was reported; the forecaster's own chance of this, stated with the estimate: 5%; middle value at least 12-fold (1.07 log units) away from the limit.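

In this assay compound 4 gives > 300 mL.min-1.g-1, which is a limit of the assay and not a number. On this nitrogen, benzoyl gives an at least 27-fold higher number from compound 3 to compound 4 (1.43 log units; beyond the scatter) and an at least 5.4-fold higher number from compound 2 to compound 4 (0.73 log units; beyond the scatter), so it stands apart from both aromatic groups tested there. A carbonyl alone does not keep the number low, since the two carbonyl-bearing groups, 4-methyl-2-oxopyrrolidin-1-yl and benzoyl(methyl)amino, lie at opposite ends, with an at least 100-fold higher number from compound 1 to compound 4 (2.00 log units; beyond the scatter).

The compounds shown leave open whether the carbonyl or the carbon-only ring of benzoyl carries this rise. An acetyl group on this nitrogen would hold the carbonyl without that ring.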